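Linker exchange at the aryl position of the shared core

This account rests on a few compounds, and the source may have more. Where it says the series, first, only, none or still open, it means among the compounds named here.

Compound 1 `Nc1cc(N)c2nc(-c3ccccc3)c(Sc3ccc(F)cc3)nc2c1` stands at the low end of the two numbers shown, though its gap to the nearest compound is within the scatter: in a functional assay on UACC-257 cells (Homo sapiens) for inhibition, read by sulforhodamine B assay, with a stated time of 48 h (a lower number here means that less compound is tolerated, a higher number that more compound is tolerated), compound 1 gives 60300 nM. Compound 3 `CCOC(=O)[C@H](CCC(=O)O)NC(=O)c1ccc(CNc2nc3cc(N)cc(N)c3nc2-c2ccccc2)cc1` gives 69200 nM in this assay. In this assay compound 2 `CCOC(=O)[C@H](CCC(=O)O)NC(=O)c1ccc(Oc2nc3cc(N)cc(N)c3nc2-c2ccccc2)cc1` returns only a limit, < 100000 nM, the line at which one of the three values sits (the limit of < 100000 nM in this assay, at which 1 of the 3 values shown sits). Compound 4 `Nc1cc(N)c2nc(-c3ccccc3)c(NCc3ccc(F)cc3)nc2c1` remains to be measured; it differs from compound 1 in one place ((4-fluorobenzyl)amino in place of (4-fluorophenyl)sulfanyl on an aromatic carbon). Among the measured compounds shown here, no measured pair shows this exchange. A step no larger than the scatter is expected, because compound 3 gives 69200 nM close to compound 1, so the estimated step of a 1.0-fold lower number from compound 1 to compound 4 (0.00 log units; within the scatter) is flat. Compound 4 is estimated at 60000 nM, between 25000 nM and 150000 nM.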

Compound 4, concentration lethal to 50% of the cells: 8910 nM
Beside the measured number, compound 4's estimate is 6.7-fold (0.83 log units) above it; measured number outside the range, below it.
By their numbers in this assay, from the lowest: compound 4; then compounds 1 and 3 (each within the scatter of the next).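

At this position, on an aromatic carbon next to the ring nitrogen, the linker to the fluorinated aryl ring matters in this assay: (4-fluorobenzyl)amino in place of (4-fluorophenyl)sulfanyl gives a 6.8-fold lower number from compound 1 to compound 4 (0.83 log units; beyond the scatter). Among the compounds shown here, this is the first single-place step, and it lies beyond the scatter. Nothing in the data shown accounts for its size.

The exchange alters both the linking atom and the chain length, so the two changes cannot be separated. A (4-fluorophenyl)amino group, with nitrogen and no added carbon, or a (4-fluorobenzyl)sulfanyl group, with sulfur and the added carbon, would separate them.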